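The source may hold more compounds than are shown below. What is called first, only, known or untested is meant among the compounds shown, and "the series" means these compounds.

Working notes on the series. In an ADME assay on HEK293 cells (Homo sapiens) for cytotoxicity, read by resazurin assay, with a stated time of 48 h (on this read-out higher numbers stand for lower toxicity in this test and lower numbers for higher toxicity in this test), compound 1 (`COc1ccc(S(=O)(=O)Nc2ccc(-c3nc4cc(NS(=O)(=O)c5ccc(OC)cc5)ccc4o3)cc2)cc1`) gives 48000 nM and compound 2 (`O=C(Nc1ccc(Sc2nc3ccccc3s2)c(Cl)c1)c1cccc(Br)c1O`) gives 68000 nM. Among the compounds with values here, these two values lie within the scatter of each other, so compound 1 stands level with the only other measured compound. Within the data shown here, no step between measured compounds is available, so the data offer no direct guide to the change under review.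

Compound 3 (`COc1ccc(S(=O)(=O)Nc2ccc3oc(-c4ccc(NS(=O)(=O)c5cc(Br)ccc5OC)cc4)nc3c2)cc1`) departs from compound 1 in one place: 5-bromo-2-methoxyphenyl in place of 4-methoxyphenyl on a sulfonyl sulfur. In words, 5-bromo-2-methoxyphenyl stands in place of 4-methoxyphenyl on a sulfonyl sulfur.

Taking compound 1 at 48000 nM as the base, no step beyond the scatter is expected in this assay, and no direction can be argued. The expected change is a 1.1-fold lower number from compound 1 to compound 3 (0.03 log units; within the scatter). For compound 3 the estimated value is 45000 nM, with an expected range of 18000 nM to 110000 nM.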

Compound 3, half-maximal cytotoxic concentration: 18000 nM
Compound 3: the middle estimate sits 2.5-fold (0.40 log units) above what was measured; the measured number falls inside the stated range.
By their numbers in this assay, from the lowest: compound 3; then compounds 1 and 2 (each within the scatter of the next).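

In this assay, within the data shown here, the swap of 5-bromo-2-methoxyphenyl for 4-methoxyphenyl on a sulfonyl sulfur gives a 2.7-fold lower number from compound 1 to compound 3 (0.43 log units; beyond the scatter) and provides the first step, showing that the number responds to the group at this place. The step is beyond the scatter but modest, and it carries the 5-bromo and 2-methoxy features of the entering group together, so it cannot be assigned to either one. Nothing available bears on the reason for this lower number.

As far as these compounds go, it remains open whether 5-bromo or 2-methoxy alone would give a step of this size, and whether the same swap on the other sulfonyl sulfur of the core of compound 1 would read the same way. From the compounds shown here alone, the response of this place to a different kind of group, such as an amine or a carboxylic acid on the ring, also remains open.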